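The source may hold more compounds than are shown below. What is called first, only, known or untested is meant among the compounds shown, and "the series" means these compounds.

Measured compounds:
- compound 1, `Cc1ccc(-c2csc(N3C(=O)c4ccccc4C3=O)n2)cc1`: 38400 nM
- compound 2, `N#Cc1ccc(-c2csc(N3C(=O)c4ccccc4C3=O)n2)cc1`: 40300 nM

Compound 1 holds the lowest of the two numbers in a functional assay on PC-3 cells (Homo sapiens) for antiproliferative activity, read by MTT assay, with a stated time of 48 h; a lower number here means a stronger inhibitor, a higher number a weaker inhibitor; compound 2 sits nearest, and the step of a 1.0-fold higher number from compound 1 to compound 2 (0.02 log units; within the scatter) is within the scatter, so the two compounds are not separable on these data.

Compound 3, `Cc1ccc(-c2csc(N3C(=O)c4ccc(F)cc4C3=O)n2)cc1`, has not been measured. It differs from compound 1 by fluoro in place of hydrogen on an aromatic carbon; the change thus sits on the fused bicyclic part of the shared core, not on the pendant aryl ring where compound 1 and compound 2 differ.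

Among the measured compounds shown here, the only measured step, a 1.0-fold higher number from compound 1 to compound 2 (0.02 log units; within the scatter), concerns a different place and was flat. For the measured compounds named here, no step touching the fused ring exists in the set, so nothing directly bears on the change to compound 3. Going by the values given here, with one flat step as the sole guide and no observation on the ring being altered, the expected step in this assay for compound 3 is none beyond the scatter, with a wide allowance for the unknown.

Compound 3 is therefore expected to give about 36000 nM in this assay, estimated between 14000 nM and 95000 nM, a step of a 1.1-fold lower number from compound 1 to compound 3 (0.03 log units; within the scatter) that is expected to stay within the scatter.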

Compound 3, half-maximal inhibitory concentration: 44400 nM
Beside the measured number, compound 3's estimate is 1.2-fold (0.09 log units) below it; the measured number falls inside the stated range.
By their numbers in this assay, from the lowest: compounds 1, 2 and 3 (each within the scatter of the next).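

In this assay, the first observation on the fused part of the shared core is a 1.2-fold higher number from compound 1 to compound 3 (0.06 log units; within the scatter), so the fluoro group of compound 3, meta to a fused ring and para to a fused ring, does not separate compound 3 from compound 1. The earlier step, a 1.0-fold higher number from compound 1 to compound 2 (0.02 log units; within the scatter), concerned only the pendant aryl ring, so a single change in each of the two places has now been read, and neither moves the number beyond the scatter. All three values remain in the same weak range, and no measurement on hand bears on why this substitution leaves the number unresolved.

Going by these compounds, whether a larger or different group at this same carbon, such as an amine, a methoxy group or a carboxylic acid, would give a step beyond the scatter remains open. Also open, on these data alone, is whether fluoro at the other aromatic carbons of this ring would behave as it does here, since this single position says nothing about its neighbours on the ring.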